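Methyl on the aromatic nitrogen of compound 1

The source may report more compounds than this note shows. Statements on the series, on what has been measured and on what is new or still open speak of the compounds shown alone.

In a functional assay, with a stated time of 10 min (a higher number here means a weaker inhibitor, a lower number a stronger inhibitor), compound 1 `COc1cc(/C=C/c2cc(=O)c(O)c[nH]2)cc(OC)c1` gives 11400 nM, the highest of the three numbers and beyond the scatter from both others. Compound 2 `O=c1cc(/C=C/c2ccc(O)cc2)[nH]cc1O` gives 1730 nM, and compound 3 `Cn1cc(O)c(=O)cc1/C=C/c1ccccc1` gives 2110 nM. Compound 4 `COc1cc(/C=C/c2cc(=O)c(O)cn2C)cc(OC)c1` has methyl in place of hydrogen on the aromatic nitrogen of compound 1 (methyl in place of hydrogen on an aromatic nitrogen). Among the measured compounds shown here, no measured pair isolates this change. Methyl on that nitrogen occurs in one measured structure, but it differs from compound 1 elsewhere too, so compound 3, at 2110 nM, gives only weak guidance. A small step towards a lower number is expected, perhaps none beyond the scatter. The expected step is a 1.6-fold lower number from compound 1 to compound 4 (0.21 log units; within the scatter). The estimate for compound 4 is 7000 nM, with an expected range of 2500 nM to 20000 nM.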

Compound 4, half-maximal inhibitory concentration: 3740 nM
The estimate for compound 4 lay 1.9-fold (0.27 log units) above the measured number; low and high end bracket the measured number.
By their numbers in this assay, from the lowest: compounds 2, 3 and 4 (each within the scatter of the next, the first and the last beyond it); then compound 1.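

In this assay, among the compounds shown here, methyl in place of hydrogen on the aromatic nitrogen gives a 3.0-fold lower number from compound 1 to compound 4 (0.48 log units; beyond the scatter) and this modest step, beyond the scatter, is the first change read in isolation. The position accepts methyl, and the hydrogen on that nitrogen is not required for inhibition on the core of compound 1. Nothing available accounts for the size of this step.

Open, going by these compounds, is whether a longer chain, an amine or a carboxylic acid on that nitrogen would extend the step or reverse it. Also open, on these data alone, is whether methyl gives a similar step on compound 2.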